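Azidomethyl in place of pent-1-en-1-yl on a carbonyl carbon

A few compounds are considered here, and "the series" means these few. Any claim that something is new, unique, unknown or untested is made for them only; others in the source may bear on it.

Measured in a functional assay on HCT-116 cells (Homo sapiens) for inhibition, read by MTT assay, with a stated time of 48 h; a lower number here means a stronger inhibitor, a higher number a weaker inhibitor:
- Compound 1 `COc1ccc(CN(C(=O)C=C(C)C)c2cc(OC)c(OC)c(OC)c2)cc1O` gives 290 nM
- Compound 2 `C#CC(=O)N(Cc1ccc(OC)c(O)c1)c1cc(OC)c(OC)c(OC)c1` gives 310 nM
- Compound 3 `CCC/C=C/C(=O)N(Cc1ccc(OC)c(O)c1)c1cc(OC)c(OC)c(OC)c1` gives 95 nM

Compound 3 has the lowest number of the three, and its gaps to both others lie beyond the scatter. Compound 4 `COc1ccc(CN(C(=O)CN=[N+]=[N-])c2cc(OC)c(OC)c(OC)c2)cc1O` carries azidomethyl in place of pent-1-en-1-yl on a carbonyl carbon. Three measured steps change this same place. Two are modest: a 3.1-fold lower number from compound 1 to compound 3 (0.48 log units; beyond the scatter) and a 3.3-fold lower number from compound 2 to compound 3 (0.51 log units; beyond the scatter). The third, a 1.1-fold higher number from compound 1 to compound 2 (0.03 log units; within the scatter), lies within the scatter. Azidomethyl itself is untested, but both other groups give higher numbers than pent-1-en-1-yl, so a modest rise is expected in this assay. The expected change is a 2.9-fold higher number from compound 3 to compound 4 (0.47 log units; beyond the scatter). For compound 4 the estimated value is 280 nM, with an expected range of 90 nM to 800 nM.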

Compound 4, half-maximal inhibitory concentration: 410 nM
Beside the measured number, compound 4's estimate is 1.5-fold (0.17 log units) below it; low and high end bracket the measured number.
By their numbers in this assay, from the lowest: compound 3; then compounds 1, 2 and 4 (each within the scatter of the next).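

In this assay, azidomethyl on the carbonyl carbon joins the weaker group rather than matching pent-1-en-1-yl: there is a 4.3-fold higher number from compound 3 to compound 4 (0.64 log units; beyond the scatter), while a 1.3-fold higher number from compound 2 to compound 4 (0.12 log units; within the scatter) and a 1.4-fold higher number from compound 1 to compound 4 (0.15 log units; within the scatter) show no real separation. Azidomethyl, ethynyl and 2-methylprop-1-en-1-yl now give numbers that cannot be told apart, leaving pent-1-en-1-yl alone among these four groups. No measurement shown here accounts for this difference. As far as these compounds go, what a saturated pentyl chain, a longer alkenyl chain or an amine would give on this carbonyl carbon remains open. So does whether the chain length or the double bond sets pent-1-en-1-yl apart.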